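The compounds below may be only part of what the source reports. "The series", "measured", "known", "first", "only" and "open" are said of these compounds alone.

In a physicochemical assay for lipophilicity, measured as octanol-water partition (a lower number here means a more polar compound, a higher number a more lipophilic compound), compound 2 (`CC(C)=CCC/C(C)=C/Cn1cc(-c2ccccc2)nn1`) gives 4.91 and stands second highest of the three numbers available. Compound 1 (`CC(C)=CCC/C(C)=C/CC/C(C)=C\Cn1cc(-c2ccccc2)nn1`) gives 6.95 and compound 3 (`COC(=O)c1cn(C/C=C(\C)CCC=C(C)C)nn1`) gives 3.2 on the same scale. Compound 4 (`CC(C)=CCC/C(C)=C\Cn1cc(-c2ccccc2)nn1`) has not yet been measured.

The structural change from the reference is the two compounds have the same atoms and bonds and differ only in configuration as drawn: 1 of 1 stereo elements differ; a double bond is drawn E in compound 2 and Z in compound 4 and nothing leaves or enters. One measured step links compounds that differ in one place: a number 1.71 log units lower from compound 2 to compound 3 (beyond the scatter) and it is large and beyond the scatter. That step exchanges phenyl for methoxycarbonyl on an aromatic carbon, so it shows how far this assay can move when a group is replaced, but it says nothing direct about double-bond configuration. Among the compounds with values here, compound 1 is joined to compound 2 by no one-place step, and its value shows only that the two numbers are far apart. Within the data shown here, no measured pair isolates an E and Z exchange.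

With atoms and bonds unchanged, no shift beyond the scatter is expected in either direction, and the estimated change is a number 0.01 log units lower from compound 2 to compound 4 (within the scatter) in this reading. For compound 4 the expected value is 4.9 with an estimated range from 4.55 to 5.25 in this measurement.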

Compound 4, partition coefficient: 4.91
Estimate against measurement, compound 4: 0.01 log units below; the range from low to high includes it.
By their numbers in this assay, from the lowest: compound 3; then compounds 2 and 4 (each within the scatter of the next); then compound 1.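

Notes on the series: in this assay, this is the first pair in which configuration at the double bond is the only variable: the fact that compounds 2 and 4 differ only in the configuration as drawn

The step reads no change at the digits printed from compound 2 to compound 4 (within the scatter), so at this double bond, with phenyl on the aromatic carbon and this chain length, the exchange of E for Z does not register on this scale, whereas the earlier exchange of phenyl for methoxycarbonyl gave a number 1.71 log units lower from compound 2 to compound 3 (beyond the scatter). The new compound also supplies the first one-place link to the longest chain in the set, a number 2.04 log units lower from compound 1 to compound 4 (beyond the scatter), with hydrogen in place of 3-methylbut-2-en-1-yl on a saturated chain carbon bound to a double-bonded chain carbon, so the gap to the top value can now be read as a single structural change.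

Still open, from the compounds shown here alone, is whether the E and Z exchange stays equally silent when a carboxylic acid or a primary amine takes the place of phenyl on the aromatic carbon, since this single pair carries one substituent only. Within the data shown here, the same exchange at the other configured double bonds of the longer chain also remains open, as no pair here isolates it.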